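Thiophene attachment point in a hydroxyphenyl-pyridine series

The compounds below may be only part of what the source reports. "The series", "measured", "known", "first", "only" and "open" are said of these compounds alone.

Four compounds share one core, all bearing a 3-hydroxyphenyl group, a phenyl group and a thiophene ring. Compound 1 is `Oc1cccc(-c2cc(-c3ccccc3)cc(-c3cccs3)n2)c1`, compound 2 is `Oc1cccc(-c2cc(-c3ccccc3)cc(-c3ccsc3)n2)c1`, compound 3 is `Oc1cccc(-c2cc(-c3ccccc3)nc(-c3cccs3)c2)c1`, and compound 4 is `Oc1cccc(-c2cc(-c3ccccc3)nc(-c3ccsc3)c2)c1`. The difference between the core of compound 1 and the core of compound 3 is not broken down here.

In an assay on isolated protein for inhibition of DNA topoisomerase 1 (Homo sapiens), with a stated time of 30 min, tested at 100 uM (a higher number here means a stronger effect of the compound at the concentration tested, a lower number a weaker effect), compound 1 gives 51.2%. In this assay compound 2 gives 75.8%, and compound 3 gives 9.1%, the lowest of the three numbers.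

The change from compound 1 to compound 2 is thiophen-3-yl in place of thiophen-2-yl on an aromatic carbon. This gave a number 24.6 percentage points higher from compound 1 to compound 2 (beyond the scatter). The change from compound 3 to compound 4 is thiophen-3-yl in place of thiophen-2-yl on an aromatic carbon, the same change at a place described in the same words. Whether it carries over from the core of compound 3 rests on a single pair, and compound 3 starts from a much lower number than compound 1.

Compound 4 has not been measured in this assay. Because compound 3 gives 9.1% and the same change earlier gave a number 24.6 percentage points higher from compound 1 to compound 2 (beyond the scatter), a step of about a number 15.9 percentage points higher from compound 3 to compound 4 (beyond the scatter) is expected from compound 3 to compound 4. For compound 4 the estimate is 25%, with a range from 5% to 50%.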

Compound 4, a percentage reported as inhibition, at one concentration (the size of the read-out at that concentration, not a potency): 6.9%
Compound 4: the middle estimate sits 18.1 percentage points above what was measured; the measured number falls inside the stated range.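

In this assay, the change to thiophen-3-yl from thiophen-2-yl did not carry over from one core to the other: the core of compound 1 showed a clear gain, while the core of compound 3 gave a number 2.2 percentage points lower from compound 3 to compound 4 (within the scatter), and the two steps differ: the same change on two cores in this assay, a number 24.6 percentage points higher (beyond the scatter) from compound 1 to compound 2 and a number 2.2 percentage points lower (within the scatter) from compound 3 to compound 4, 26.8 percentage points apart, beyond the scatter of two such steps. In this series, therefore, the step measured on the core of compound 1 cannot be used to predict the outcome of the same change on the core of compound 3, and on the latter core the thiophene attachment point makes no distinction in this read-out, with compound 3 at 9.1% and compound 4 at 6.9%. This does not show why the two cores behave differently, and with one pair per core and a single tested concentration it gives no general rule for any further core.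

The compounds shown leave open whether the same dependence on the core would appear with other rings in place of the thiophene, such as a furan or a pyridine. They also leave open what an amine or a carboxylic acid on the phenyl group would do to the read-out on either core.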